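The compounds below may be only part of what the source reports. "The series", "measured", "known", "first", "only" and "open" are said of these compounds alone.

Measured compounds:
compound 1 `O=C(Nc1cccc(Br)c1)N[C@@H]1C2CCN(CC2)[C@@H]1Cc1cccnc1` in an assay on a protein complex for binding affinity to Neuronal acetylcholine receptor; alpha4/beta2 (Homo sapiens) (on this read-out lower numbers stand for stronger inhibition and higher numbers for weaker inhibition), gives > 10000 nM.
compound 2 `COc1ccccc1NC(=O)N[C@@H]1C2CCN(CC2)[C@@H]1Cc1cccnc1` gives > 10000 nM.
compound 3 `O=C(Nc1ccc(F)cc1)N[C@@H]1C2CCN(CC2)[C@@H]1Cc1cccnc1` gives > 10000 nM.

For compound 3 the value > 10000 nM is a limit of the assay and not a number. The same holds for compound 2, whose value > 10000 nM is also a limit. For compound 1 the value > 10000 nM is a limit as well. Compound 1 therefore stands at the limit of > 10000 nM in this assay, at which 3 of the 3 values shown sit, together with every other compound shown. The changes of the aryl group on the amide-type nitrogen, a step that the two limits leave unreadable from compound 1 to compound 2, a step that the two limits leave unreadable from compound 1 to compound 3 and a step that the two limits leave unreadable from compound 2 to compound 3, have no readable size, both ends of each sitting at the same limit.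

Compound 4 `O=C(Nc1cccc(C(F)(F)F)c1)N[C@@H]1C2CCN(CC2)[C@@H]1Cc1cccnc1` differs from compound 1 by trifluoromethyl in place of bromo on an aromatic carbon. No measured step touches this position, and every measured value is a limit, so nothing among the shown numbers points toward a gain. Compound 4 is expected to give 15000 nM, with a range from 5000 nM to 50000 nM, most probably again reported only as a limit. The step that the limit leaves unreadable from compound 1 to compound 4 that this estimate implies is expected to stay within the scatter.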

Compound 4, inhibition constant: > 10000 nM
Compound 4 was reported as a limit; the forecaster's own chance of this, stated with the estimate: 85%; the middle value lies beyond the limit too.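

The value for compound 4 is a limit, as is that for compound 1, so the change from bromo to trifluoromethyl between them has no readable size: the limit of > 10000 nM in this assay, at which 4 of the 4 values shown sit.

The compounds shown leave open whether any aryl group on the amide-type nitrogen of the shared core gives a value that is a number.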